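From pyridin-3-yl to pyridin-4-yl: estimating compound 4

The source may report more compounds than this note shows. Statements on the series, on what has been measured and on what is new or still open speak of the compounds shown alone.

Measured in a functional assay on QGY-7703 cells (Homo sapiens) for cytotoxicity, read by MTT assay, with a stated time of 24 h; a lower number here means a stronger inhibitor, a higher number a weaker inhibitor:
- compound 1 `O=C1/C(=C/c2cccnc2)CN(S(=O)(=O)c2ccc(C(F)(F)F)cc2)C/C1=C\c1ccccc1F`: 4500 nM
- compound 2 `O=C1/C(=C/c2cccnc2)CN(S(=O)(=O)c2ccc(F)cc2)C/C1=C\c1ccccc1F`: 15300 nM
- compound 3 `N#Cc1ccc(S(=O)(=O)N2C/C(=C\c3cccnc3)C(=O)/C(=C/c3ccccc3F)C2)cc1`: 15800 nM

Compound 2 sits at the weaker end of this small set. It cannot be told apart from its nearest neighbour, with a 1.0-fold higher number from compound 2 to compound 3 (0.01 log units; within the scatter), while compound 1 gives the lowest number, with a 3.4-fold higher number from compound 1 to compound 2 (0.53 log units; beyond the scatter).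

Compound 4 `O=C1/C(=C/c2ccncc2)CN(S(=O)(=O)c2ccc(F)cc2)C/C1=C\c1ccccc1F` has the same atoms as compound 2, joined differently: pyridin-4-yl in place of pyridin-3-yl on a double-bonded chain carbon bound to a double-bonded ring carbon. For the measured compounds named here, no measured step tests this swap, because all three change a group on an aromatic carbon elsewhere in the molecule. They offer only a rough sense of scale: the largest, a 3.5-fold higher number from compound 1 to compound 3 (0.55 log units; beyond the scatter), is modest, and it removes trifluoromethyl, which compound 2 already lacks. With no evidence for a direction, no change beyond the scatter is expected in this assay. The estimated step is a 1.1-fold lower number from compound 2 to compound 4 (0.04 log units; within the scatter). For compound 4 the expected value is 14000 nM, with an estimated range of 6000 nM to 32000 nM.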

Compound 4, half-maximal inhibitory concentration: 9100 nM
Beside the measured number, compound 4's estimate is 1.5-fold (0.19 log units) above it; the measured number falls inside the stated range.
By their numbers in this assay, from the lowest: compound 1; then compounds 4, 2 and 3 (each within the scatter of the next).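

In this assay, swapping pyridin-3-yl for pyridin-4-yl on a double-bonded chain carbon bound to a double-bonded ring carbon gives a 1.7-fold lower number from compound 2 to compound 4 (0.23 log units; within the scatter), so this first direct test of the position shows no change that can be separated from ordinary assay scatter. The two groups have the same atoms and the same donor and acceptor counts, so this pair tests only how the pyridine ring is joined, and here that difference does not register clearly. No available information explains the result.

Going by these compounds, whether the swap would read the same with trifluoromethyl in place of fluoro, as in compound 1, remains open. Also open, on these data alone, is how this position would respond to a different group, such as pyridin-2-yl or a phenyl ring carrying an amine or a carboxylic acid.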